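Bromomethyl to dimethyl on the pendant aryl

This account rests on a few compounds, and the source may have more. Where it says the series, first, only, none or still open, it means among the compounds named here.

Measured compounds:
compound 1 `CCC1=C(O)c2c(oc(-c3ccc(F)cc3)cc2=O)C(CC)(CC)C1=O` — 1.85 uM
compound 2 `CCC1=C(O)c2c(oc(-c3ccc(CBr)cc3)cc2=O)C(CC)(CC)C1=O` — 27.9 uM
compound 3 `CCC1=C(O)c2c(oc(-c3ccc(OC)c(C)c3C)cc2=O)C(CC)(CC)C1=O` — 0.28 uM

Three compounds share a core and differ only in the aryl group attached to it. In a functional assay on KBVIN cells (Homo sapiens) for antiproliferative activity, read by sulforhodamine B assay, with a stated time of 3 days (a lower number here means that less compound is needed, a higher number that more compound is needed for the effect), compound 2 gives the highest number of the three. Among the compounds with values here, the one measured step that changes a single place, a 15-fold higher number from compound 1 to compound 2 (1.18 log units; beyond the scatter), runs from compound 1 to compound 2 and is large. Within the data shown here, compound 3 gives 0.28 uM, the lowest number of the set; no single-place step links compound 3 to compound 2, so only the two values themselves can be compared.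

Compound 4 `CCC1=C(O)c2c(oc(-c3cc(C)ccc3C)cc2=O)C(CC)(CC)C1=O` is not yet measured. Its change from compound 2: 2,5-dimethylphenyl in place of 4-(bromomethyl)phenyl on an aromatic carbon. The bromomethyl group that accompanied the large rise in a 15-fold higher number from compound 1 to compound 2 (1.18 log units; beyond the scatter) is removed, and the entering group carries two methyls, as the aryl of compound 3 does. Among the measured compounds shown here, no measured step has exactly this pair, so the expectation rests on removing the bromomethyl rather than on a matched precedent.

The expected step is a 19-fold lower number from compound 2 to compound 4 (1.27 log units; beyond the scatter), a drop roughly back toward compound 1. Compound 4 is estimated at 1.5 uM, within 0.4 uM to 6 uM.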

Compound 4, concentration for half-maximal effect: 3.41 uM
The estimate for compound 4 lay 2.3-fold (0.36 log units) below the measured number, within the range that was stated.
By their numbers in this assay, from the lowest: compound 3; then compounds 1 and 4 (each within the scatter of the next); then compound 2.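

In this assay, 2,5-dimethylphenyl in place of 4-(bromomethyl)phenyl gives an 8.2-fold lower number from compound 2 to compound 4 (0.91 log units; beyond the scatter) at this aromatic carbon next to the ring oxygen, so the high number of compound 2 is not shared by a second aryl group carrying no bromine. Set against 4-fluorophenyl, the same group gives a 1.8-fold higher number from compound 1 to compound 4 (0.27 log units; within the scatter) and so cannot be told apart from it in this read-out, which leaves compound 2 alone at the high end among these three. No measurement here bears on why the 4-(bromomethyl)phenyl group differs from the other two.

Still open, going by these compounds, is whether the bromine itself or the substitution pattern on the aryl accounts for the gap. A plain methyl, an aminomethyl or a carboxylic acid in the place of the bromomethyl would separate these readings.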